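Compound 1 and the 3-bromophenyl swap in compound 4

The compounds below may be only part of what the source reports. "The series", "measured", "known", "first", "only" and "open" are said of these compounds alone.

For the measured compounds named here, in a functional assay on HT-29 cells (Homo sapiens) for inhibition, read by sulforhodamine B assay, with a stated time of 72 h (a lower number here means a stronger inhibitor, a higher number a weaker inhibitor), compound 1 `COc1cc2c(Nc3ccc(F)c(Cl)c3)ncnc2cc1OCCCCCCn1ccnc1[N+](=O)[O-]` gives 1840 nM as the lowest of the two numbers so far. Compound 2 `COc1cc2c(Nc3ccc(F)c(Cl)c3)ncnc2cc1OCCOCCn1ccnc1[N+](=O)[O-]` reads 5520 nM with 2-(2-nitro-1H-imidazol-1-yl)ethoxy in place of 4-(2-nitro-1H-imidazol-1-yl)butyl on the chain. That change is a 3.0-fold higher number from compound 1 to compound 2 (0.48 log units; beyond the scatter) and leaves the aryl group untouched. Compound 3 `COc1cc2c(Nc3ccc(OCc4cccc(F)c4)c(Cl)c3)ncnc2cc1OCCCCCCn1ccnc1[N+](=O)[O-]` stands at > 50000 nM as a limit of the assay and not a number. Going by the values given here, its (3-fluorobenzyl)oxy in place of fluoro on an aromatic carbon makes an at least 27-fold higher number from compound 1 to compound 3 (1.43 log units; beyond the scatter) and is the only measured change on the aryl group.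

Compound 4 `COc1cc2c(Nc3cccc(Br)c3)ncnc2cc1OCCCCCCn1ccnc1[N+](=O)[O-]` has not yet been measured. Its change from compound 1 is 3-bromophenyl in place of 3-chloro-4-fluorophenyl on a nitrogen on an aromatic ring and in words it puts 3-bromophenyl in place of 3-chloro-4-fluorophenyl on a nitrogen on an aromatic ring. The step of an at least 27-fold higher number from compound 1 to compound 3 (1.43 log units; beyond the scatter) bears on this only loosely: compound 3 gained a whole (3-fluorobenzyl)oxy, and compound 4 carries no such group. The expected move in this assay is a 1.4-fold higher number from compound 1 to compound 4 (0.13 log units; within the scatter) and no step beyond the scatter is expected, although a slightly higher number is the likelier direction. For compound 4 the estimated value is 2500 nM with an expected range from 800 nM to 8000 nM in this assay.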

Compound 4, half-maximal inhibitory concentration: 4300 nM
Beside the measured number, compound 4's estimate is 1.7-fold (0.24 log units) below it; low and high end bracket the measured number.
By their numbers in this assay, from the lowest: compound 1; then compounds 4 and 2 (each within the scatter of the next). At a limit, above all of these: compound 3.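

In this assay, 3-bromophenyl in place of 3-chloro-4-fluorophenyl on a nitrogen on an aromatic ring gives a 2.3-fold higher number from compound 1 to compound 4 (0.37 log units; beyond the scatter) and so shows that this position responds even to an exchange of one substituted phenyl for another, with no added benzyl ether. For the compounds shown here, compound 3, at > 50000 nM, is a limit of the assay and not a number, which makes the step to compound 4 the only change on this aryl group with a number at both ends. Nothing in the data shown accounts for the size of this step.

Because the chlorine and the fluorine both leave in the same swap, the compounds shown do not separate what each one contributes, and how a 3-chlorophenyl, a 4-fluorophenyl or a 3-ethynylphenyl group would read on that nitrogen stays open. Also open, from the compounds shown here alone, is whether the step would hold with the 2-(2-nitro-1H-imidazol-1-yl)ethoxy chain of compound 2, or with an amine in place of the 2-nitro-1H-imidazol-1-yl group at the end of the chain.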